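This account rests on a few compounds, and the source may have more. Where it says the series, first, only, none or still open, it means among the compounds named here.

Compound 2 `C#Cc1cn([C@@H]2O[C@H](CO)[C@@H](O)[C@@H]2O)c(=O)[nH]c1=O` is the starting point here. In an ADME assay on HEL cells (Homo sapiens) for cytotoxicity (a higher number here means that more compound is tolerated, a lower number that less compound is tolerated), compound 2 gives 200000 nM. Compound 1 `C[Si](C)(C)C#Cc1cn([C@H]2C[C@H](O)[C@@H](CO)O2)c(=O)[nH]c1=O`, with a different sugar, gives 200000 nM in this assay, so compound 2 stands level with compound 1 within the scatter. Compound 3 `C[Si](C)(C)C#Cc1cn([C@@H]2O[C@H](CO)[C@@H](O)[C@@H]2O)c(=O)[nH]c1=O` keeps the sugar of compound 2 and differs from it by a group of 4 heavy atoms (3 carbon, 1 silicon; no ring) in place of a hydrogen atom, on a triple-bonded carbon. Among the compounds with values here, no measured pair differs in exactly this way, so the size of this step is not known from measurement. Because compound 1 already tolerates 200000 nM with that group in place, no shift beyond the scatter is expected. The expected step here is no change at the digits printed from compound 2 to compound 3 (within the scatter). Compound 3 is expected to give 200000 nM in this assay, within 100000 nM to 300000 nM.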

Compound 3, minimum cytotoxic concentration: 200000 nM
Compound 3: the middle estimate sits on the measured number at the digits printed; measured number inside the range.
By their numbers in this assay, from the lowest: compounds 1, 2 and 3 (each within the scatter of the next).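

In this assay, the group of 4 heavy atoms in place of hydrogen on the triple-bonded carbon gives no change at the digits printed from compound 2 to compound 3 (within the scatter), so on this sugar the two compounds cannot be told apart. With that group kept, hydroxy in place of hydrogen on a saturated ring carbon gives no change at the digits printed from compound 1 to compound 3 (within the scatter), so this sugar change also leaves the reading unmoved. No supporting data explain either result. As far as these compounds go, whether an amine or a longer carbon chain on the triple-bonded carbon would read the same remains open.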